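One Carbon More on the Chain of Compound 3

A few compounds are considered here, and "the series" means these few. Any claim that something is new, unique, unknown or untested is made for them only; others in the source may bear on it.

In a functional assay on cells (Homo sapiens) for antiproliferative activity, read by MTT assay, with a stated time of 48 h (on this read-out lower numbers stand for stronger inhibition and higher numbers for weaker inhibition), compound 1 `CCN(CC)CCCn1c(N)c(-c2nc3ccccc3[nH]2)c2nc(C#N)c(C#N)nc21` gives 28900 nM and compound 2 `CCN(CC)CCCn1c(N)c(-c2nc3ccccc3n2C)c2nc(C#N)c(C#N)nc21` gives 6750 nM. Compound 3 `CCN(CC)CCn1c(N)c(-c2nc3cc(Cl)ccc3[nH]2)c2nc(C#N)c(C#N)nc21` gives only a limit, > 50000 nM, so it stands at the limit of > 50000 nM in this assay, at which 1 of the 3 values shown sits.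

Compound 4 `CCN(CC)CCCn1c(N)c(-c2nc3cc(Cl)ccc3[nH]2)c2nc(C#N)c(C#N)nc21` has not yet been measured. It departs from compound 3 in one place: (diethylamino)methyl in place of diethylamino on a saturated chain carbon, two bonds along the chain from an aromatic nitrogen. This is (diethylamino)methyl in place of diethylamino on a saturated chain carbon, two bonds along the chain from an aromatic nitrogen, which turns 2-(diethylamino)ethyl into 3-(diethylamino)propyl.

Among the compounds with values here, no measured step covers this change. The only one available, a 4.3-fold lower number from compound 1 to compound 2 (0.63 log units; beyond the scatter), is methyl in place of hydrogen on an aromatic nitrogen, a different place, so it offers only a sense of scale. More relevant is that compound 4 carries the same 3-(diethylamino)propyl chain as compound 1, which gives a real number, 28900 nM. On that basis, a modest move to a lower number is expected in this assay, with the estimated step being an at least 2.2-fold lower number from compound 3 to compound 4 (0.35 log units; beyond the scatter). Compound 4 is estimated at 22000 nM, with an expected range from 8000 nM to 50000 nM.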

Compound 4, half-maximal inhibitory concentration: 23200 nM
Compound 4: the middle estimate sits 1.1-fold (0.02 log units) below what was measured, and the stated range covers the measured number.
By their numbers in this assay, from the lowest: compound 2; then compounds 4 and 1 (each within the scatter of the next). At a limit, above all of these: compound 3.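

In this assay, going from 2-(diethylamino)ethyl to 3-(diethylamino)propyl on the saturated chain carbon gives an at least 2.1-fold lower number from compound 3 to compound 4 (0.33 log units; beyond the scatter), the first step read at this position, and it shows that one carbon more in this chain moves the number beyond the scatter when the chloro group is present. The true size of that step remains unknown because compound 3 is held only by a limit of the assay: the limit of > 50000 nM in this assay, at which 1 of the 4 values shown sits.

With the 3-(diethylamino)propyl chain held constant, chloro in place of hydrogen on an aromatic carbon gives a 1.2-fold lower number from compound 1 to compound 4 (0.10 log units; within the scatter), whereas 5-chloro-1H-benzimidazol-2-yl in place of 1-methyl-1H-benzimidazol-2-yl gives a 3.4-fold higher number from compound 2 to compound 4 (0.54 log units; beyond the scatter), so the exchange of these two groups registers in this assay while the chloro alone does not.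

The compounds shown leave open whether the chain step would hold without the chloro group, and whether a longer chain, such as 4-(diethylamino)butyl, would carry the trend further. They also leave open what a cyclic amine such as morpholine would do in place of diethylamino, and whether the methyl on the aromatic nitrogen would give the same step alongside the chloro group.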